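Pyridin-2-yl for 4-fluorophenyl: working notes on compound 4

The compounds below may be only part of what the source reports. "The series", "measured", "known", "first", "only" and "open" are said of these compounds alone.

Compound 1 `COc1ccccc1CC1(OC)CCN(c2ccc(C(=O)NS(=O)(=O)c3ccc(N[C@H](CCN(C)C)CSc4ccccc4)c([N+](=O)[O-])c3)cc2)CC1` gives 1.6 nM in an assay on isolated protein for displacement of a labelled ligand from Apoptosis regulator Bcl-2 (Homo sapiens), read by fluorescence polarization; a higher number here means a weaker inhibitor, a lower number a stronger inhibitor.
Compound 2 `COC1(Cc2ccccc2-c2ccccc2)CCN(c2ccc(C(=O)NS(=O)(=O)c3ccc(N[C@H](CCN(C)C)CSc4ccccc4)c([N+](=O)[O-])c3)cc2)CC1` gives < 1 nM in this assay, a limit rather than a number.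
Compound 3 `CN(C)CC[C@H](CSc1ccccc1)Nc1ccc(S(=O)(=O)NC(=O)c2ccc(N3CCC(=Cc4ccc(F)cc4)CC3)cc2)cc1[N+](=O)[O-]` gives 3.4 nM in this assay.

Of the two numbers shown, compound 3 has the higher one; compound 1 sits lower. Compound 4 `CN(C)CC[C@H](CSc1ccccc1)Nc1ccc(S(=O)(=O)NC(=O)c2ccc(N3CCC(=Cc4ccccn4)CC3)cc2)cc1[N+](=O)[O-]` carries pyridin-2-yl in place of 4-fluorophenyl on a double-bonded chain carbon bound to a double-bonded ring carbon. Going by the values given here, the only measured step, an at least 1.6-fold lower number from compound 1 to compound 2 (0.20 log units; that floor lies within the scatter), changes a different part of the shared core and ends at a limit (the limit of < 1 nM in this assay, at which 1 of the 3 values shown sits); it bears little on this swap. Among the compounds with values here, no step here exchanges one aryl for another on that chain carbon, so a change beyond the scatter is not expected. The step from compound 3 to compound 4 is estimated at a 1.0-fold higher number from compound 3 to compound 4 (0.01 log units; within the scatter). Compound 4 is therefore expected near 3.5 nM, within 1.5 nM to 8 nM.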

Compound 4, inhibition constant: 46 nM
For compound 4 the middle estimate is 13-fold (1.12 log units) below the measured one; measured number above the stated range.
By their numbers in this assay, from the lowest: compound 1; then compound 3; then compound 4. At a limit, below all of these: compound 2.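

In this assay, the aryl group on this double-bonded chain carbon matters: pyridin-2-yl in place of 4-fluorophenyl gives a 14-fold higher number from compound 3 to compound 4 (1.13 log units; beyond the scatter). The earlier compounds shown here held no exchange at this place, and this step shows that one six-membered aromatic ring does not simply stand in for another here. Nothing in the data shown accounts for the size of this step. Open, from the compounds shown here alone, is whether any ring nitrogen at this place has this effect, or only that of pyridin-2-yl. Unsubstituted phenyl, pyridin-3-yl or pyridin-4-yl on the same carbon would separate these cases.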